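The source may hold more compounds than are shown below. What is called first, only, known or untested is meant among the compounds shown, and "the series" means these compounds.

In a functional assay on HeLa cells (Homo sapiens) for antiproliferative activity, read by sulforhodamine B assay, with a stated time of 48 h (a higher number here means a weaker inhibitor of growth, a lower number a stronger inhibitor of growth), compound 3 `COc1ccc(-c2nn(-c3ccccc3)cc2C(=O)NCc2cn(Cc3ccc(Cl)cc3)nn2)cc1` gives 6400 nM, the highest number among the three measured compounds; compound 2 `COc1cc(Cn2cc(CNC(=O)c3cn(-c4ccccc4)nc3-c3ccc(F)cc3)nn2)cc(OC)c1OC` gives 2100 nM and compound 1 `O=C(NCc1cn(Cc2ccc(Cl)cc2)nn1)c1cn(-c2ccccc2)nc1-c1ccccc1` gives 600 nM. Within the data shown here, the one single-point step on record is an 11-fold higher number from compound 1 to compound 3 (1.03 log units; beyond the scatter). Compound 4 `COc1ccc(-c2nn(-c3ccccc3)cc2C(=O)NCc2cn(Cc3cc(OC)c(OC)c(OC)c3)nn2)cc1` differs from compound 3 by 3,4,5-trimethoxyphenyl in place of 4-chlorophenyl on a saturated chain carbon bound to an aromatic nitrogen. Among the measured compounds shown here, no measured step bears directly on this change; the only hint is that compound 2, which carries the same 3,4,5-trimethoxyphenyl group but also a different substituent elsewhere, sits between compound 1 and compound 3, so the change is not expected to shift the number by much. The step of a 1.3-fold higher number from compound 3 to compound 4 (0.10 log units; within the scatter) is therefore expected to stay near the scatter, and compound 4 is estimated at 8000 nM, with a range from 3000 nM to 20000 nM.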

Compound 4, concentration for 50% growth inhibition: 1700 nM
Compound 4: the middle estimate sits 4.7-fold (0.67 log units) above what was measured; the measured number lies below the stated range.
By their numbers in this assay, from the lowest: compound 1; then compounds 4 and 2 (each within the scatter of the next); then compound 3.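

In this assay the group on a saturated chain carbon bound to an aromatic nitrogen clearly counts: 3,4,5-trimethoxyphenyl in place of 4-chlorophenyl gives a 3.8-fold lower number from compound 3 to compound 4 (0.58 log units; beyond the scatter) and so offsets part of the loss seen in an 11-fold higher number from compound 1 to compound 3 (1.03 log units; beyond the scatter). With 3,4,5-trimethoxyphenyl in this place, methoxy in place of fluoro on an aromatic carbon gives a 1.2-fold lower number from compound 2 to compound 4 (0.09 log units; within the scatter) and makes no real difference. No evidence is available to explain either step. Still open, as far as these compounds go, is how the compound with hydrogen on that aromatic carbon and 3,4,5-trimethoxyphenyl would compare with compound 1. Also open, from the compounds shown here alone, is whether an amine or a longer chain in place of the aryl group would keep this activity.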